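A few compounds are considered here, and "the series" means these few. Any claim that something is new, unique, unknown or untested is made for them only; others in the source may bear on it.

Compound 1, `COc1ccc(-c2cc(-c3ccccc3)no2)c(OCCCN2CCCCC2)c1`, gives 15% in a functional assay on the whole organism (blood, strain Sprague-Dawley albino) with Rattus norvegicus as the target, with stated times of 30 min and 24 h, at a dose of 100 mg/kg by the oral route; a lower number here means less inhibition, a higher number more inhibition at the dose given (going by the name of the read-out).
Compound 2, `COc1ccc(-c2cc(-c3ccccc3)no2)c(OCCCN2CCCC2)c1`, gives 11.2% in this assay.

Going by the values given here, compound 2 holds the lower of the two numbers, but its only neighbour is compound 1, and the step of a number 3.8 percentage points lower from compound 1 to compound 2 (within the scatter) lies within the scatter, so the two cannot be told apart. Compound 3, `CCN(CC)CC(O)COc1cc(OC)ccc1-c1cc(-c2ccccc2)no1`, has not yet been measured. It differs from compound 2 as follows: 2-(diethylamino)-1-hydroxyethyl in place of 2-(pyrrolidin-1-yl)ethyl on a saturated chain carbon bound to an oxygen on an aromatic ring. Among the compounds with values here, the single measured step, a number 3.8 percentage points lower from compound 1 to compound 2 (within the scatter), concerns a different exchange, pyrrolidin-1-yl for piperidin-1-yl, and was small; no measured pair shows a hydroxy group entering or a diethylamino group replacing a ring amine. On that evidence the step of a number 1.8 percentage points higher from compound 2 to compound 3 (within the scatter) is expected to stay within the scatter, with no clear direction. For compound 3 the estimate in this assay is 13%, with a range from 2% to 26%.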

Compound 3, a percentage reported as inhibition, in the whole organism at one dose (the size of the read-out at that dose, not a potency): 11.4%
The estimate for compound 3 lay 1.6 percentage points above the measured number; the measured number falls inside the stated range.
By their numbers in this assay, from the lowest: compounds 2, 3 and 1 (each within the scatter of the next).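

Moving to 2-(diethylamino)-1-hydroxyethyl gives a number 0.2 percentage points higher from compound 2 to compound 3 (within the scatter) and a number 3.6 percentage points lower from compound 1 to compound 3 (within the scatter) in this assay. At this place, on a saturated chain carbon bound to an oxygen on an aromatic ring, a larger change than the earlier swap of one ring amine for another therefore still gives no readable difference: the ring is gone and a hydroxy group has entered. No measurement at hand offers an explanation for this result.

Going by these compounds, the ring loss and the hydroxy group arrive together, so their separate contributions remain unknown, and they could offset each other. On these data alone, it also remains open whether a morpholine or a carboxylic acid in place of the amine, or a longer chain, would move the number beyond the scatter.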